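Replacing neopentyloxy with phenyl on compound 2's aromatic ring

A few compounds are considered here, and "the series" means these few. Any claim that something is new, unique, unknown or untested is made for them only; others in the source may bear on it.

Compound 2 `CN(C)C(=O)c1cccnc1NCCCN1CCN(c2ccccc2OCC(C)(C)C)CC1` gives 50.1 nM in a functional assay on aorta for antagonist activity at Alpha-1D adrenergic receptor (Rattus norvegicus) (on this read-out lower numbers stand for tighter binding and higher numbers for weaker binding), the highest number among the two measured compounds; the nearest is compound 1 `CN(C)C(=O)c1cccnc1NCCCN1CCN(c2ccccc2)CC1`, which gives 15.9 nM. Going by the values given here, the only measured step that bears on the new compound is a 3.2-fold higher number from compound 1 to compound 2 (0.50 log units; beyond the scatter). Compound 3 `CN(C)C(=O)c1cccnc1NCCCN1CCN(c2ccccc2-c2ccccc2)CC1` differs from compound 2 by phenyl in place of neopentyloxy on an aromatic carbon. Among the compounds with values here, no measured pair shows what phenyl does at this place, so the expectation rests on compound 2 alone, with the knowledge that a large group at this carbon gave a modest rise. Because a 3.2-fold higher number from compound 1 to compound 2 (0.50 log units; beyond the scatter) was modest, compound 3 is expected to stay near compound 2, with a step of a 1.3-fold lower number from compound 2 to compound 3 (0.10 log units; within the scatter) that may well fall within the scatter. Compound 3 is therefore estimated at 40 nM, within a range from 15 nM to 110 nM.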

Compound 3, dissociation constant: 63.1 nM
Compound 3: middle estimate off by 1.6-fold (0.20 log units), on the low side; the range from low to high includes it.
By their numbers in this assay, from the lowest: compound 1; then compounds 2 and 3 (each within the scatter of the next).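

Exchanging neopentyloxy for phenyl, which has the same count of heavy atoms but no oxygen and no hydrogen-bond acceptor, gives a 1.3-fold higher number from compound 2 to compound 3 (0.10 log units; within the scatter) in this assay, so this assay does not separate the open chain from the aromatic ring at this aromatic carbon. Phenyl in place of hydrogen gives a 4.0-fold higher number from compound 1 to compound 3 (0.60 log units; beyond the scatter), so a second large group also raises the number over compound 1, and the modest rise is not peculiar to neopentyloxy. Nothing available explains why these two groups read alike.

Going by these compounds, it remains open whether a small group such as fluorine or methoxy on this carbon would stay near compound 1 or move towards compound 2 and compound 3. On these data alone, it is equally open how an amine or a carboxylic acid would read here.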